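Trading a Quinolin-2-yl Amide for 3,4-Dichlorophenyl

This account rests on a few compounds, and the source may have more. Where it says the series, first, only, none or still open, it means among the compounds named here.

In a functional assay on MCF7 cells (Homo sapiens) for antiproliferative activity, read by MTT assay, with a stated time of 72 h (on this read-out higher numbers stand for weaker inhibition and lower numbers for stronger inhibition), compound 1 `Cc1cc(NCCN2CCCC2)nc2ccc(NC(=O)c3ccc(Cl)c(Cl)c3)cc12` gives 1280 nM while compound 2 `CCN1CCN(c2cc(C)c3cc(NC(=O)c4ccc5ccccc5n4)ccc3n2)CC1` gives 7060 nM as the higher of the two numbers, which means weaker inhibition. Compound 3 `CCN1CCN(c2cc(C)c3cc(NC(=O)c4ccc(Cl)c(Cl)c4)ccc3n2)CC1` differs from compound 2 in one place, with 3,4-dichlorophenyl in place of quinolin-2-yl on a carbonyl carbon. Compound 1 also carries 3,4-dichlorophenyl on a carbonyl carbon and reads 1280 nM in this assay but differs elsewhere, so only part of that gap is expected to carry over. The expected change is a 2.5-fold lower number from compound 2 to compound 3 (0.40 log units; beyond the scatter) toward stronger inhibition. Compound 3 is estimated at 2800 nM (1000 nM to 7500 nM).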

Compound 3, half-maximal inhibitory concentration: 1380 nM
Compound 3: middle estimate off by 2.0-fold (0.31 log units), on the high side; the measured number falls inside the stated range.
By their numbers in this assay, from the lowest: compounds 1 and 3 (each within the scatter of the next); then compound 2.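

With 4-ethylpiperazin-1-yl kept in place, the group on the carbonyl carbon clearly matters: 3,4-dichlorophenyl in place of quinolin-2-yl gives stronger inhibition (a 5.1-fold lower number from compound 2 to compound 3 (0.71 log units; beyond the scatter)). The other exchange, 4-ethylpiperazin-1-yl in place of (2-(pyrrolidin-1-yl)ethyl)amino on an aromatic carbon, leaves the reading within the scatter (a 1.1-fold higher number from compound 1 to compound 3 (0.03 log units; within the scatter)) while 3,4-dichlorophenyl stays on the carbonyl carbon. No measurement here explains either step.

From the compounds shown here alone, whether a plain phenyl or a 4-methoxyphenyl on the carbonyl carbon would read like 3,4-dichlorophenyl remains open. So does how quinolin-2-yl behaves alongside (2-(pyrrolidin-1-yl)ethyl)amino.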